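The source may hold more compounds than are shown below. What is called first, only, known or untested is meant among the compounds shown, and "the series" means these compounds.

Measured compounds in an assay on isolated protein for inhibition of Amine oxidase [flavin-containing] B (Homo sapiens), read by fluorescence, with a stated time of 20 min; on this read-out higher numbers stand for weaker inhibition and lower numbers for stronger inhibition:

- compound 1 `CC/C(C)=N\Nc1nc(-c2cccc([N+](=O)[O-])c2)cs1`: compound 1 gives 351 nM
- compound 2 `CCCCC/C(CC)=N\Nc1nc(-c2cccc([N+](=O)[O-])c2)cs1`: compound 2 gives 355 nM
- compound 3 `CCCC/C(CC)=N\Nc1nc(-c2cccc([N+](=O)[O-])c2)cs1`: compound 3 gives 182 nM

Compound 1 sits second highest of the three numbers; its gap to compound 2 and its gap to compound 3 both lie within the scatter, so the three measured compounds are not separated in this assay.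

Compound 4 `CCCCCC/C(C)=N\Nc1nc(-c2cccc([N+](=O)[O-])c2)cs1` differs from compound 1 by butyl in place of hydrogen on a saturated chain carbon, two bonds along the chain from a carbon with a double bond to nitrogen. Among the measured compounds shown here, the only single-site step measured, a 2.0-fold lower number from compound 2 to compound 3 (0.29 log units; within the scatter), also concerns chain length at the hydrazone carbon and stays within the scatter. Compounds 1 and 2, which differ at both chains, give numbers that are likewise within the scatter of each other. Lengthening the chain therefore carries no expected effect beyond the scatter in this assay, in either direction.

The expected step is a 1.2-fold lower number from compound 1 to compound 4 (0.07 log units; within the scatter), essentially flat. Compound 4 is expected to give 300 nM, with a range from 120 nM to 750 nM.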

Compound 4, half-maximal inhibitory concentration: 626 nM
Beside the measured number, compound 4's estimate is 2.1-fold (0.32 log units) below it, within the range that was stated.
By their numbers in this assay, from the lowest: compounds 3, 1, 2 and 4 (each within the scatter of the next, the first and the last beyond it).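

In this assay, butyl in place of hydrogen at this position, two bonds along the chain from a carbon with a double bond to nitrogen, gives a 1.8-fold higher number from compound 1 to compound 4 (0.25 log units; within the scatter). The same difference read as ethyl to hexyl is a far larger change in chain length than the single methyl of a 2.0-fold lower number from compound 2 to compound 3 (0.29 log units; within the scatter), and it too stays within the scatter, so this position tolerates the added butyl with no resolved change in the number. No supporting evidence is available to explain this tolerance.

As far as these compounds go, whether a chain longer than hexyl would produce a step beyond the scatter remains open. So does the outcome of a phenyl ring, an amine or a carboxylic acid at this position, since the compounds shown carry only unbranched saturated chains here.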